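Hydroxy to methoxy in compound 3

A few compounds are considered here, and "the series" means these few. Any claim that something is new, unique, unknown or untested is made for them only; others in the source may bear on it.

Compound 1 `C=CC(=O)Nc1nc(-c2ccccc2)cs1`: 18600 nM
Compound 2 `C=CC(=O)Nc1nc(-c2ccccc2Cl)cs1`: 12300 nM
Compound 3 `C=CC(=O)Nc1nc(-c2ccccc2O)cs1`: > 30000 nM

In a functional assay on HCT-116 cells (Homo sapiens) for antiproliferative activity, read by MTT assay, with a stated time of 72 h (a lower number here means a stronger inhibitor, a higher number a weaker inhibitor), compound 3 gives only a limit, > 30000 nM. Compound 4 `C=CC(=O)Nc1nc(-c2ccccc2OC)cs1` differs from it by methyl in place of hydrogen on an oxygen on an aromatic ring, hydroxy to methoxy. Two measured steps introduce that hydroxy. The first is an at least 1.6-fold higher number from compound 1 to compound 3 (0.20 log units; that floor lies within the scatter), and the second is an at least 2.4-fold higher number from compound 2 to compound 3 (0.38 log units; beyond the scatter). Neither step tests a methoxy directly, and a 1.5-fold lower number from compound 1 to compound 2 (0.18 log units; within the scatter) shows that chloro in place of hydrogen changes little. A modest move back towards compound 1 is therefore expected, towards a lower number. The expected change is an at least 1.8-fold lower number from compound 3 to compound 4 (0.27 log units; that floor lies within the scatter). For compound 4 the estimated value is 16000 nM, with an expected range of 8000 nM to 30000 nM.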

Compound 4, half-maximal inhibitory concentration: > 30000 nM
Compound 4: only a limit was reported; the forecaster's own chance of this, stated with the estimate: 15%; middle value at least 1.8-fold (0.27 log units) away from the limit.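

In this assay, replacing the hydroxy hydrogen with methyl gives no readable value: compound 4, like compound 3, reports only a limit, so the step between them cannot be read. Methoxy in place of chloro gives an at least 2.4-fold higher number from compound 2 to compound 4 (0.38 log units; beyond the scatter), whereas methoxy in place of hydrogen gives an at least 1.6-fold higher number from compound 1 to compound 4 (0.20 log units; that floor lies within the scatter). Hydroxy and methoxy thus both leave the series at the same limit: the limit of > 30000 nM in this assay, at which 2 of the 4 values shown sit.

As far as these compounds go, how far compound 3 and compound 4 lie past that limit stays open. So does whether an amine or an ethoxy in the same place would give a readable value.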